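This account rests on a few compounds, and the source may have more. Where it says the series, first, only, none or still open, it means among the compounds named here.

Measured compounds in a functional assay on PC-3 cells (Homo sapiens) for cytotoxicity, read by MTT assay, with a stated time of 24 h, tested at 100 uM; a higher number here means a weaker effect of the compound at the concentration tested, a lower number a stronger effect:
compound 1, `O=C(/C=C/c1cnn(-c2ccccc2)n1)c1ccccc1`: 6.38%
compound 2, `Cc1ccc(C(=O)/C=C/c2cnn(-c3ccccc3)n2)c(C)c1`: 0%
compound 3, `COc1ccc(C(=O)/C=C/c2cnn(-c3ccccc3)n2)c(OC)c1`: 5.37%

Compound 1 gives the largest of the three figures in this assay, but the gap to compound 3 and the gap to compound 2 both lie within the usual scatter of this kind of measurement, so the three compounds read alike: each shows only a small effect at the concentration tested. Among the compounds with values here, no single-point step between measured compounds is available, so nothing in the measured set shows how far a change on the carbonyl carbon moves the read-out.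

Compound 4, `O=C(/C=C/c1cnn(-c2ccccc2)n1)c1cccs1`, has not yet been measured. It differs from compound 1 in one place: thiophen-2-yl in place of phenyl on a carbonyl carbon.

Because the three values of compound 1, compound 2 and compound 3 sit together within the scatter, the step of a number 0.4 percentage points lower from compound 1 to compound 4 (within the scatter) is expected to be none beyond the scatter. Compound 4 is therefore estimated to give about 6% in this assay, within a range from 0% to 20%.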

Compound 4, a percentage reported as activity, at one concentration (the size of the read-out at that concentration, not a potency): 24.2%
Estimate against measurement, compound 4: 18.2 percentage points below; the measured number lies above the stated range.
By their numbers in this assay, from the lowest: compounds 2, 3 and 1 (each within the scatter of the next); then compound 4.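

Thiophen-2-yl in place of phenyl on a carbonyl carbon gives a number 17.8 percentage points higher from compound 1 to compound 4 (beyond the scatter) in this assay and so a weaker effect at the concentration tested. This is the only single-place step among the compounds shown, and it establishes that the group at this position can move the read-out beyond the scatter, which the closely grouped earlier values could not reveal. Nothing available accounts for the size or direction of this step.

As far as these compounds go, with a single step, it remains open whether the change holds when the rest of the core of compound 1 is altered. From the compounds shown here alone, it also remains open how the read-out would respond to an amine or a longer chain in place of the phenyl on the carbonyl carbon.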